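Swapping the aryl hydrazide for a butyl amide

A few compounds are considered here, and "the series" means these few. Any claim that something is new, unique, unknown or untested is made for them only; others in the source may bear on it.

Compound 1 `O=C(Nc1sc2c(c1C(=O)NNc1ccccc1)CCCCC2)NS(=O)(=O)c1ccccc1` gives 26300 nM in a functional assay on cells (Cancer cell lines, Homo sapiens) for inhibition, with a stated time of 48 h; a lower number here means a stronger inhibitor of growth, a higher number a weaker inhibitor of growth.
Compound 2 `O=C(Nc1sc2c(c1C(=O)NNc1ccc(Br)cc1)CCCCC2)NS(=O)(=O)c1ccccc1` gives 11500 nM in this assay.
Compound 3 `O=C(Nc1sc2c(c1C(=O)NNc1ccc(Cl)cc1)CCCCC2)NS(=O)(=O)c1ccccc1` gives only a limit of the assay, > 100000 nM, in this assay.

Among the three measured compounds, compound 3 stands at the weak end, since its number in this assay is a limit and not a value; the step of an at least 8.6-fold higher number from compound 2 to compound 3 (0.93 log units; beyond the scatter) and the step of an at least 3.8-fold higher number from compound 1 to compound 3 (0.58 log units; beyond the scatter) both point in that direction, as recorded by the limit of > 100000 nM in this assay, at which 1 of the 3 values shown sits. Compound 4 `CCCCNC(=O)c1c(NC(=O)NS(=O)(=O)c2ccccc2)sc2c1CCCCC2` differs from compound 3 by butyl in place of (4-chlorophenyl)amino on an amide-type nitrogen. Among the measured compounds shown here, no measured step touches this position: the steps of a 2.3-fold lower number from compound 1 to compound 2 (0.36 log units; beyond the scatter) and an at least 3.8-fold higher number from compound 1 to compound 3 (0.58 log units; beyond the scatter) only exchange one substituent on the aromatic ring, and they pull in opposite directions, so they give no clear guide to removing that whole ring and putting a butyl chain in its place. Compound 4 is therefore expected to land somewhere within the range spanned by compounds 1 and 2 and compound 3, and its estimated number in this assay is 40000 nM, between 10000 nM and 150000 nM. This estimate corresponds to an expected step of an at least 2.5-fold lower number from compound 3 to compound 4 (0.39 log units; beyond the scatter), with considerable uncertainty.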

Compound 4, concentration for 50% growth inhibition: 72300 nM
The estimate for compound 4 lay 1.8-fold (0.26 log units) below the measured number; the measured number falls inside the stated range.
By their numbers in this assay, from the lowest: compound 2; then compound 1; then compound 4. At a limit, above all of these: compound 3.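

Compound 4 shows that the aromatic ring and its attached amino nitrogen can both be removed from this amide nitrogen with growth inhibition still measurable in this assay. The change nevertheless gives a 2.7-fold higher number from compound 1 to compound 4 (0.44 log units; beyond the scatter), with the bromo ring it gives a 6.3-fold higher number from compound 2 to compound 4 (0.80 log units; beyond the scatter), and with the chloro ring it gives an at least 1.3-fold lower number from compound 3 to compound 4 (0.14 log units; that floor lies within the scatter), so both hydrazides with real numbers sit lower than the butyl amide, while compound 3 goes against that pattern. Compound 3 has only a limit of the assay, so that last step is only a floor: the limit of > 100000 nM in this assay, at which 1 of the 4 values shown sits.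

Going by these compounds, the butyl swap removes the ring and the extra nitrogen together, so the share of each in these gaps stays open. Also open, on these data alone, is how a benzyl group, a longer chain or a butyl chain ending in an amine or a carboxylic acid would behave on this nitrogen.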